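Removing a methyl from a ring nitrogen of compound 1

The source may report more compounds than this note shows. Statements on the series, on what has been measured and on what is new or still open speak of the compounds shown alone.

Compound 1 (`COc1ccc(N(C)c2nc(C)nc3c2nc(C)n3C)cc1`) gives 7400 nM in a functional assay (BAEC cells, Bos taurus) for inhibition, read by cell counting, with a stated time of 3 days (a higher number here means a weaker inhibitor, a lower number a stronger inhibitor), and sits at the low end of the numbers shown, level with compound 3 (`COc1ccc(N(C)c2nc(C)nc3c2ncn3C)cc1`) at 9300 nM within the scatter. Compound 2 (`Cc1ccc(N(C)c2nc(C)nc3c2nc(C)n3C)cc1`) records > 100000 nM as a limit and not a number.

Compound 4 (`COc1ccc(N(C)c2nc(C)nc3[nH]c(C)nc23)cc1`) has hydrogen in place of methyl on an aromatic nitrogen. For the measured compounds named here, no measured step makes this exact change. The nearest is the same replacement on an aromatic carbon (a 1.3-fold higher number from compound 1 to compound 3 (0.10 log units; within the scatter)), which stays within the scatter. Going by the values given here, the replacement of methoxy by methyl is far larger (an at least 13-fold higher number from compound 1 to compound 2 (1.13 log units; beyond the scatter)), but it lies at another place on the molecule, so it shows only that a single change to compound 1 can cost much. A small step toward a higher number is therefore expected in this assay, hardly beyond the scatter. The estimated step runs (a 1.6-fold higher number from compound 1 to compound 4 (0.21 log units; within the scatter)). Compound 4 is expected at 12000 nM (estimated range 4000 nM to 50000 nM).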

Compound 4, half-maximal inhibitory concentration: 8900 nM
Compound 4: the middle estimate sits 1.3-fold (0.13 log units) above what was measured; the measured number falls inside the stated range.
By their numbers in this assay, from the lowest: compounds 1, 4 and 3 (each within the scatter of the next). At a limit, above all of these: compound 2.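

Hydrogen in place of methyl on an aromatic nitrogen stays within the scatter in this assay (a 1.2-fold higher number from compound 1 to compound 4 (0.08 log units; within the scatter)), so the methyl on this nitrogen of the five-membered aromatic ring is not needed for a reading level with that of compound 1. The earlier step on an aromatic carbon also stays within the scatter (a 1.3-fold higher number from compound 1 to compound 3 (0.10 log units; within the scatter)), so with the new step, neither of these two replacements of methyl by hydrogen separates its compound from compound 1. Nothing measured here accounts for this result. 

The compounds shown leave open how a longer chain, an amine or a carboxylic acid would read on this nitrogen, as only methyl and hydrogen stand there. Also open, going by these compounds, is whether hydrogen on this nitrogen would read the same with methyl in place of methoxy.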